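Naphthyl amides on an inward rectifier channel: compound 3

A few compounds are considered here, and "the series" means these few. Any claim that something is new, unique, unknown or untested is made for them only; others in the source may bear on it.

Measured so far:
compound 1 `O=C(NCCCCCCCl)Nc1c(C(O)(C(F)(F)F)C(F)(F)F)ccc2ccccc12`, 4840 nM
compound 2 `Cc1ccccc1C(=O)Nc1c(C(O)(C(F)(F)F)C(F)(F)F)ccc2ccccc12`, 5550 nM

Compound 1 and compound 2 share a core carrying the hexafluoro-hydroxypropyl group and an amide-type nitrogen. In an assay on LtK cells with ATP-sensitive inward rectifier potassium channel 11 (Homo sapiens) as the target (on this read-out higher numbers stand for an effect only at larger amounts of compound and lower numbers for an effect already at smaller amounts), compound 1 gives 4840 nM, and compound 2 gives 5550 nM, the highest of the two numbers; the step of a 1.1-fold higher number from compound 1 to compound 2 (0.06 log units; within the scatter) is within the scatter, so the two values are read as equal.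

Compound 3 `O=C(Nc1c(C(O)(C(F)(F)F)C(F)(F)F)ccc2ccccc12)c1cccc(Br)c1` has not yet been measured. It differs from compound 2 by 3-bromophenyl in place of 2-methylphenyl on a carbonyl carbon. For the measured compounds named here, no measured step touches a change of this kind; the only step in hand, a 1.1-fold higher number from compound 1 to compound 2 (0.06 log units; within the scatter), swaps a chain-bearing amino group for an aryl group at the same carbonyl carbon and gives no movement beyond the scatter. On that basis no step beyond the scatter is expected for compound 3 in this assay, that is a 1.0-fold lower number from compound 2 to compound 3 (0.00 log units; within the scatter).

For compound 3 the estimate in this assay is 5500 nM, with a range from 1800 nM to 17000 nM.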

Compound 3, half-maximal effective concentration: 80 nM
Compound 3: the middle estimate sits 69-fold (1.84 log units) above what was measured; the measured number lies below the stated range.
By their numbers in this assay, from the lowest: compound 3; then compounds 1 and 2 (each within the scatter of the next).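

In this assay the group on the carbonyl carbon is no longer a silent position, as the earlier pair suggested: 3-bromophenyl in place of 2-methylphenyl gives a 69-fold lower number from compound 2 to compound 3 (1.84 log units; beyond the scatter) and is a large step. Against the chain-bearing urea partner the same group gives a 61-fold lower number from compound 1 to compound 3 (1.78 log units; beyond the scatter) and is also large, so among these compounds an aryl group at this carbon does not by itself set the value, since compound 2 stays level with compound 1 while compound 3 stands clear of both. No measured data here account for the size of this step.

The change replaces methyl with bromine and moves the substituent at once, so the two cannot be separated on these compounds. Going by these compounds, how an unsubstituted phenyl, a chlorophenyl or a nitrile-bearing phenyl would read at this carbon remains open.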